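The compounds below may be only part of what the source reports. "The series", "measured", "known", "first", "only" and "open" are said of these compounds alone.

Measured in a functional assay on SF-268 cells (Homo sapiens) for inhibition, read by sulforhodamine B assay, with a stated time of 48 h; on this read-out lower numbers stand for stronger inhibition of growth and higher numbers for weaker inhibition of growth:
Compound 1 `O=C(Cc1csc2nc(-c3ccc(Br)cc3)cn12)N/N=C/c1ccccc1O`: < 100000 nM, a limit.
Compound 2 `O=C(Cc1csc2nc(-c3ccc(Br)cc3)cn12)N/N=C/c1ccc(O)cc1`: < 100000 nM, a limit.

Compound 2 has no number, only a limit: the limit of < 100000 nM in this assay, at which 2 of the 2 values shown sit. Compound 3 `COc1cccc(OC)c1/C=N/NC(=O)Cc1csc2nc(-c3ccc(Br)cc3)cn12` carries 2,6-dimethoxyphenyl in place of 4-hydroxyphenyl on a carbon with a double bond to nitrogen. Within the data shown here, the only measured step is a step that the two limits leave unreadable from compound 1 to compound 2, so it offers no size to carry over, and no measured compound holds 2,6-dimethoxyphenyl. No direction can be expected with confidence in this assay. The expected step, an estimate only, is a step that the limit leaves unreadable from compound 2 to compound 3. Compound 3 is estimated at 30000 nM, with an expected range of 5000 nM to 100000 nM.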

Compound 3, concentration for 50% growth inhibition: < 100000 nM
Compound 3 ended at the assay's limit; the forecaster's own chance of this, stated with the estimate: 50%; the middle value is on the limit's open side.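

Among these compounds, compound 1, compound 2 and compound 3 all sit at a limit in this assay, so no step among them can be read: the limit of < 100000 nM in this assay, at which 3 of the 3 values shown sit. As far as these compounds go, whether 2-hydroxyphenyl, 4-hydroxyphenyl and 2,6-dimethoxyphenyl differ at all in growth inhibition stays open.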